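Methylcarbamoyl to carbamoyl: expected effect on potency

This account rests on a few compounds, and the source may have more. Where it says the series, first, only, none or still open, it means among the compounds named here.

Measured in an assay for inhibition of serine/threonine-protein kinase PLK2 (Homo sapiens), read by FRET and Z'-LYTE, with a stated time of 1 h; on this read-out lower numbers stand for stronger inhibition and higher numbers for weaker inhibition:
compound 1 `CCC1C(=O)N(C)c2cnc(Nc3ccc(S(=O)(=O)NC)cc3)nc2N1c1ccn(C)n1`: 71.6 nM
compound 2 `CCC1C(=O)N(C)c2cnc(-n3ccc4cc(C(=O)NC)ccc43)nc2N1c1ccn(C)n1`: 218 nM
compound 3 `CC[C@@H]1C(=O)N(C)c2cnc(-n3ccc4cc(C(=O)NC5CCCC5)ccc43)nc2N1C1CCCC1`: 7.06 nM

Compound 2 gives the highest number of the three in this assay. Compound 1 gives a lower number, and the gap between them lies beyond the scatter; compound 3 gives the lowest number, and its gap to compound 2 also lies beyond the scatter. Among the compounds with values here, compound 3 differs from compound 2 in more than one place, so its two values show only that the combined changes lower the number; no single step can be read from that pair.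

Compound 4 `CCC1C(=O)N(C)c2cnc(-n3ccc4cc(C(N)=O)ccc43)nc2N1c1ccn(C)n1` is not yet measured. It differs from compound 2 by one change: hydrogen in place of methyl on an amide-type nitrogen. Within the data shown here, no measured pair in this set shows this change on its own, so there is nothing in the data to set its size. The change removes a single methyl, and the expected step in this assay is a 1.1-fold higher number from compound 2 to compound 4 (0.06 log units; within the scatter), none beyond the scatter in either direction. Compound 4 is therefore expected to give about 250 nM in this assay, within the range from 100 nM to 650 nM.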

Compound 4, half-maximal inhibitory concentration: 384 nM
Estimate against measurement, compound 4: 1.5-fold (0.19 log units) below; measured number inside the range.
By their numbers in this assay, from the lowest: compound 3; then compound 1; then compounds 2 and 4 (each within the scatter of the next).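

In this assay, within the data shown here, hydrogen in place of methyl on an amide-type nitrogen whose other neighbour is the carbonyl carbon gives a 1.8-fold higher number from compound 2 to compound 4 (0.25 log units; within the scatter), the first step that can be read at a single place. Compounds 2 and 4 therefore cannot be told apart in this assay, so at this position, with the rest of compound 2 held constant, the methyl can be exchanged for hydrogen with no effect beyond the scatter. Nothing available here accounts for this result.

As far as these compounds go, it remains open whether a longer chain such as ethyl or hydroxyethyl, or a second methyl on the same nitrogen, would separate from compounds 2 and 4, and whether a carboxylic acid in place of the carbamoyl group would do so. Among these compounds, it also remains open whether the methyl-to-hydrogen exchange gives a step of similar size when other groups are carried on the shared core, since only this one pair shows it.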